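Urea in place of sulfonyl on the piperazine-type ring

The source may report more compounds than this note shows. Statements on the series, on what has been measured and on what is new or still open speak of the compounds shown alone.

In a functional assay on MDA-MB-436 cells (Homo sapiens) for antiproliferative activity, read by MTT assay, with a stated time of 48 h (a lower number here means a stronger inhibitor, a higher number a weaker inhibitor), compound 1 `C=CS(=O)(=O)N1CCN(c2nc(OC[C@H]3CCCN3C)nc3sccc23)CC1` is reported as > 50000 nM and that value is a limit. Compound 2 `C=CS(=O)(=O)N1CCN(c2ncnc3sc(-c4ccc(N5CCN(C)CC5)cc4)cc23)[C@@H](C)C1` gives 6920 nM in this assay and compound 3 `CN1CCN(c2ccc(-c3cc4c(N5CCN(S(=O)(=O)C6CC6)CC5)ncnc4s3)cc2)CC1` gives 10600 nM there, so these two lie within the scatter of each other. Compound 4 `CN1CCN(c2ccc(-c3cc4c(N5CCN(C(=O)Nc6cccc(F)c6)CC5)ncnc4s3)cc2)CC1` has (3-fluorophenyl)carbamoyl in place of cyclopropylsulfonyl on an amine nitrogen in a ring, counted as (3-fluorophenyl)carbamoyl in place of cyclopropylsulfonyl on an amine nitrogen in a ring for this change. Within the data shown here, no measured pair isolates this change, so the starting point is compound 3 at 10600 nM and no step beyond the scatter is expected in this assay here. The expected step of a 1.2-fold lower number from compound 3 to compound 4 (0.07 log units; within the scatter) is therefore small, with a wide margin. Compound 4 is estimated at 9000 nM with an expected range from 3000 nM to 30000 nM in this assay.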

Compound 4, half-maximal inhibitory concentration: 18300 nM
Compound 4: the middle estimate sits 2.0-fold (0.31 log units) below what was measured; measured number inside the range.
By their numbers in this assay, from the lowest: compounds 2, 3 and 4 (each within the scatter of the next, the first and the last beyond it). At a limit, above all of these: compound 1.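

In this assay, (3-fluorophenyl)carbamoyl in place of cyclopropylsulfonyl on an amine nitrogen in a ring gives a 1.7-fold higher number from compound 3 to compound 4 (0.24 log units; within the scatter), the first step read at this position. The position thus takes a larger group, carrying an aromatic ring and a hydrogen-bond donor, with no step beyond the scatter. Nothing measured here bears on this result.

Open, as far as these compounds go, is whether an amine or a carboxylic acid on the phenyl ring of the carbamoyl group would move the number beyond the scatter. The part played by the fluorine also remains unresolved.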